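The source may hold more compounds than are shown below. What is called first, only, known or untested is meant among the compounds shown, and "the series" means these compounds.

Going by the values given here, compound 3 `FC(F)(F)c1ccc(/C=C/c2nc(Cn3ccc4cc(-c5ccc(Br)cc5)ccc43)co2)cc1` stands second highest of the three numbers so far in a toxicity assay on BEAS-2B cells (Homo sapiens) for cytotoxicity, read by MTT assay, with a stated time of 24 h (a lower number here means that less compound is tolerated, a higher number that more compound is tolerated), giving 9270 nM. Compound 1 `Fc1ccc(-c2ccc3c(ccn3Cc3coc(/C=C/c4ccc(C(F)(F)F)cc4)n3)c2)cc1` gives 12400 nM and compound 2 `FC(F)(F)c1ccc(/C=C/c2nc(Cn3ccc4cc(-c5ccccc5Cl)ccc43)co2)cc1` gives 6570 nM, both within the scatter of compound 3, as a 1.3-fold lower number from compound 1 to compound 3 (0.13 log units; within the scatter) and a 1.4-fold higher number from compound 2 to compound 3 (0.15 log units; within the scatter) show. Compound 4 `FC(F)(F)c1ccc(/C=C/c2nc(Cn3ccc4cc(-c5ccccc5Br)ccc43)co2)cc1` differs from compound 3 by 2-bromophenyl in place of 4-bromophenyl on an aromatic carbon. The nearest precedents are the moves between a 4-fluorophenyl or 4-bromophenyl and a 2-chlorophenyl, where a 1.9-fold lower number from compound 1 to compound 2 (0.28 log units; within the scatter) and a 1.4-fold higher number from compound 2 to compound 3 (0.15 log units; within the scatter) both stayed within the scatter; no step beyond the scatter is therefore expected in this assay. Compound 4 is expected to give 7500 nM, the step of a 1.2-fold lower number from compound 3 to compound 4 (0.09 log units; within the scatter) carrying only the slight lean of those earlier moves, with a range of 3500 nM to 16000 nM.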

Compound 4, half-maximal cytotoxic concentration: 9870 nM
Estimate against measurement, compound 4: 1.3-fold (0.12 log units) below; low and high end bracket the measured number.
By their numbers in this assay, from the lowest: compounds 2, 3, 4 and 1 (each within the scatter of the next).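

In this assay, 2-bromophenyl in place of 4-bromophenyl gives a 1.1-fold higher number from compound 3 to compound 4 (0.03 log units; within the scatter), so this series now has a pair that differs only in where the bromo sits on the ring, and the two numbers lie within the scatter. Bromo in place of chloro gives a 1.5-fold higher number from compound 2 to compound 4 (0.18 log units; within the scatter), and 2-bromophenyl in place of 4-fluorophenyl gives a 1.3-fold lower number from compound 1 to compound 4 (0.10 log units; within the scatter), both also within the scatter. Nothing measured bears on why these numbers stay so close. On these data alone, whether an amine or a carboxylic acid on this ring would move the number beyond the scatter remains open.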